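Variation at the chain carbon next to the amide

The source may hold more compounds than are shown below. What is called first, only, known or untested is meant among the compounds shown, and "the series" means these compounds.

Three members of this series share one core and differ only at the saturated chain carbon bound to the carbonyl carbon. Compound 1 `COC(=O)NC(CC(=O)N1CCC(Cn2c(C)nc3cnccc32)CC1)c1ccccc1` carries a (methoxycarbonyl)amino group there and in a functional assay (plasma) with Oryctolagus cuniculus as the target (a higher number here means a weaker inhibitor, a lower number a stronger inhibitor), compound 1 gives 12 nM. Compound 2 `CCCC(CC(=O)N1CCC(Cn2c(C)nc3cnccc32)CC1)c1ccccc1` carries propyl instead, and in this assay compound 2 gives 11 nM. Compound 3 `Cc1nc2cnccc2n1CC1CCN(C(=O)CC(c2ccccc2)c2ccccc2)CC1` carries a second phenyl, and in this assay compound 3 gives 7.6 nM. Each of the three steps stays within the scatter: a 1.1-fold lower number from compound 1 to compound 2 (0.04 log units; within the scatter), a 1.6-fold lower number from compound 1 to compound 3 (0.20 log units; within the scatter) and a 1.4-fold lower number from compound 2 to compound 3 (0.16 log units; within the scatter). Compound 2 thus stands in the middle of three numbers that cannot be told apart.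

Compound 4 `Cc1nc2cnccc2n1CC1CCN(C(=O)CC(C)(O)c2ccccc2)CC1` has not been measured. 1-hydroxy-1-phenylethyl in place of 1-phenylbutyl on a saturated chain carbon bound to a carbonyl carbon The three known steps bear on it, since all replace one group at this carbon with another of quite different character, and none moved the number beyond the scatter. A hydrogen-bond donor is already present in compound 1 without penalty. The expected step is therefore a 1.6-fold higher number from compound 2 to compound 4 (0.21 log units; within the scatter), that is, no change beyond the scatter, with a slight lean towards a weaker inhibitor for the smaller group. Compound 4 is estimated at 18 nM, within a range of 6 nM to 55 nM.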

Compound 4, half-maximal inhibitory concentration: 6.9 nM
The estimate for compound 4 lay 2.6-fold (0.42 log units) above the measured number; measured number inside the range.
By their numbers in this assay, from the lowest: compounds 4, 3, 2 and 1 (each within the scatter of the next).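

In this assay the exchange of 1-phenylbutyl for 1-hydroxy-1-phenylethyl on a saturated chain carbon bound to a carbonyl carbon gives a 1.6-fold lower number from compound 2 to compound 4 (0.20 log units; within the scatter) and so leaves no change that can be read. The entering group brings one hydrogen-bond donor and one hydrogen-bond acceptor where the leaving group has none, so this position takes a hydroxy-bearing group as well as the (methoxycarbonyl)amino, propyl and phenyl variants seen before. The tolerance at this carbon therefore extends to a group with oxygen carried directly on its first carbon, while the phenyl ring stays in place on both sides of the step.

The compounds shown leave open whether a primary amine or a carboxylic acid in place of the hydroxy group would also stay within the scatter. They also leave open what a longer chain, such as 1-phenylhexyl, or a group without the phenyl ring, such as cyclohexyl, would do at this carbon.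

Nothing available here bears on why this step stays within the scatter.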